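Swapping the Sulfur-Linked Ring of a Benzothiazole Amide

The source may hold more compounds than are shown below. What is called first, only, known or untested is meant among the compounds shown, and "the series" means these compounds.

Compound 1 `Cc1cc(C)cc(C(=O)Nc2nc3ccc(NC(=O)CSc4ccc(Cl)cc4)cc3s2)c1`: 65100 nM
Compound 2 `O=C(CSc1ncccn1)Nc1ccc2nc(NC(=O)c3ccc(C(F)(F)F)cc3)sc2c1`: 2220 nM
Compound 3 `O=C(CSc1cccc(O)c1)Nc1ccc2nc(NC(=O)c3cccs3)sc2c1`: 7020 nM

Of the compounds shown here, three sharing one core have been tested in a functional assay on HCT-116 cells (Homo sapiens) for antiproliferative activity, read by MTT assay, with a stated time of 72 h; a higher number here means a weaker inhibitor, a lower number a stronger inhibitor. Compound 2 gives 2220 nM, the lowest number of the three, and its gaps to compound 3 and to compound 1 both lie beyond the usual scatter, so among these three compound 2 is the strongest inhibitor. Compound 3 gives 7020 nM in this assay, and compound 1 gives 65100 nM.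

Compound 4 `O=C(CSc1ccc2ccccc2c1)Nc1ccc2nc(NC(=O)c3ccc(C(F)(F)F)cc3)sc2c1` has not yet been measured. It differs from compound 2 in one place: naphthalen-2-yl in place of pyrimidin-2-yl on a sulfur. For the measured compounds named here, no pair of measured compounds differing only in this way is available, so the size of the step is not known from data. With nothing to show otherwise, the change is expected to move the number by no more than the scatter, with a slight lean toward a weaker inhibitor; the step from compound 2 to compound 4 is estimated at a 1.4-fold higher number from compound 2 to compound 4 (0.13 log units; within the scatter). Compound 4 is therefore expected to give about 3000 nM in this assay, within a range of 800 nM to 12000 nM.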

Compound 4, half-maximal inhibitory concentration: 300 nM
For compound 4 the middle estimate is 10-fold (1.00 log units) above the measured one, outside the stated range (below it).
By their numbers in this assay, from the lowest: compound 4; then compound 2; then compound 3; then compound 1.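

In this assay, the group on the sulfur proves able to change the result: naphthalen-2-yl in place of pyrimidin-2-yl gives a 7.4-fold lower number from compound 2 to compound 4 (0.87 log units; beyond the scatter) and lies beyond the usual scatter. For the compounds shown here, the earlier compounds differ from one another in more than one place, so this is the first step that isolates this position, and here two carbon-only aromatic rings replace one ring holding two nitrogens. No measurement shown here explains this step.

The compounds shown cannot separate the effect of the second ring from that of losing the ring nitrogens, and quinolin-2-yl on the same sulfur, with two fused rings and one nitrogen, would help to divide the two. From the compounds shown here alone, whether the step carries over to compounds with a different amide group on the shared core also remains open.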